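The source may hold more compounds than are shown below. What is called first, only, known or untested is meant among the compounds shown, and "the series" means these compounds.

Of the compounds shown here, three built on one shared core have been tested in a functional assay on SUP-B15 cells (Homo sapiens) for antiproliferative activity, with a stated time of 72 h; a lower number here means that less compound is needed, a higher number that more compound is needed for the effect. Compound 1 `COc1ccc(-c2cc(=O)c3c(OC)cc(OC)cc3n2C)cc1` gives 28000 nM. Compound 2 `COc1cc(OC)c2c(=O)cc(C(=O)Nc3cc(C(F)(F)F)ccc3Oc3ccccc3OC)[nH]c2c1` gives only > 53400 nM, which is a limit of the assay rather than a number, namely (the limit of > 53400 nM in this assay, at which 1 of the 3 values shown sits). Compound 3 `COc1cc(OC)c2c(=O)cc(C(=O)Nc3ccc(Oc4ccc([N+](=O)[O-])cc4)cc3)[nH]c2c1` gives 4300 nM, the lower of the two numbers available, and its gap to compound 1 lies beyond the usual scatter. Compound 4 `COc1cc(OC)c2c(=O)cc(C(=O)Nc3ccc(S(=O)(=O)c4ccccc4)cc3)[nH]c2c1` has not yet been measured in this assay. It differs from compound 3 in a single place: phenylsulfonyl in place of 4-nitrophenoxy on an aromatic carbon. Among the measured compounds shown here, no two measured compounds differ in just one place, so the size of such a swap cannot be read from a measured step. The amide and the shared core stay untouched, and the group that enters carries nearly the same count of heavy atoms as the one that leaves. The expected step of a 1.4-fold higher number from compound 3 to compound 4 (0.14 log units; within the scatter) for compound 4 is small and, if anything, towards a higher number. Compound 4 is thus estimated at 6000 nM, in a range from 1500 nM to 25000 nM.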

Compound 4, half-maximal effective concentration: > 70600 nM
Compound 4 ended at the assay's limit; the forecaster's own chance of this, stated with the estimate: 10%; middle value at least 11-fold (1.07 log units) from the limit.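

In this assay, among the compounds shown here, placing phenylsulfonyl instead of 4-nitrophenoxy on this aromatic carbon, para to a large group, gives an at least 16-fold higher number from compound 3 to compound 4 (1.21 log units; beyond the scatter), the first measured step that changes only one place. Compound 4 ended at a limit of the assay, so it has no exact number: the limit of > 70600 nM in this assay, at which 1 of the 4 values shown sits. The step therefore shows that this position is sensitive to the choice of group, even though the leaving and entering groups each carry one six-membered aromatic ring of carbon only and the amide and shared core stay the same.

The swap changes both the link to that ring and the nitro group, and the compounds shown cannot separate these two changes. On these data alone, it also remains open whether plain phenoxy, or a phenoxy group carrying an amine or a carboxylic acid, would keep the activity of compound 3.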